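The source may hold more compounds than are shown below. What is called first, only, known or untested is meant among the compounds shown, and "the series" means these compounds.

Measured compounds:
compound 1 `CN1CCCN(CCn2ccc3ccc(Br)cc32)CC1` – 31 nM
compound 2 `C=C(C)c1ccc2ccn(CCN3CCCN(C)CC3)c2c1` – 70 nM
compound 3 `CC(C)CN1CCCN(CCn2ccc3ccc(Br)cc32)CC1` – 37 nM

In an assay on HEK293 cells for binding affinity to 5-hydroxytryptamine receptor 7 (Homo sapiens), read by radioligand binding (on this read-out lower numbers stand for stronger inhibition and higher numbers for weaker inhibition), compound 3 gives the second highest of the three numbers, yet its nearest neighbour compound 1 lies within the scatter, as the step of a 1.2-fold higher number from compound 1 to compound 3 (0.08 log units; within the scatter) shows, and even compound 2 is not separated from it beyond the scatter. Compound 4 `Brc1ccc2ccn(CCN3CCCN(CC4CC4)CC3)c2c1` is not yet measured. It differs from compound 3 by cyclopropyl in place of isopropyl on a saturated chain carbon bound to an amine nitrogen in a ring. Among the measured compounds shown here, only one measured step touches this place: a 1.2-fold higher number from compound 1 to compound 3 (0.08 log units; within the scatter), which stayed within the scatter when isopropyl replaced hydrogen there. The step of a 2.3-fold higher number from compound 1 to compound 2 (0.35 log units; beyond the scatter) concerns the aromatic carbon instead and does not bear on it. The expected step is therefore a 1.1-fold lower number from compound 3 to compound 4 (0.02 log units; within the scatter), none beyond the scatter. Compound 4 is estimated at 35 nM, within 15 nM to 80 nM.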

Compound 4, inhibition constant: 9 nM
For compound 4 the middle estimate is 3.9-fold (0.59 log units) above the measured one; the whole stated range lies above it.
By their numbers in this assay, from the lowest: compound 4; then compounds 1, 3 and 2 (each within the scatter of the next, the first and the last beyond it).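

Until now this place looked indifferent in this assay. Putting isopropyl there left the number within the scatter, but cyclopropyl gives a 4.1-fold lower number from compound 3 to compound 4 (0.61 log units; beyond the scatter) and also a 3.4-fold lower number from compound 1 to compound 4 (0.54 log units; beyond the scatter) in the same place. Isopropyl and cyclopropyl have the same count of carbons, so what separates these two compounds is the three-membered ring. Nothing measured here explains the difference. Still open, as far as these compounds go, is whether larger rings in this place, such as cyclobutyl or cyclopentyl, give similar numbers, and whether cyclopropyl has the same effect when 1-methylethenyl replaces bromo on the aromatic carbon.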